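Chloro for benzyloxy on a weak cytotoxic indole acrylic acid

The source may hold more compounds than are shown below. What is called first, only, known or untested is meant among the compounds shown, and "the series" means these compounds.

Three compounds of a shared core were tested in a functional assay on A549 cells (Homo sapiens) for cytotoxicity, read by MTT assay, with a stated time of 72 h; a lower number here means a stronger inhibitor, a higher number a weaker inhibitor. Compound 1 `COc1cccc(/C(=C\c2cn(C(C)=O)c3ccc(OCc4ccccc4)cc23)C(=O)O)c1` gives 45200 nM. Compound 2 `COc1ccc(/C(=C\c2c[nH]c3ccc(OCc4ccccc4)cc23)C(=O)O)cc1` gives "not determined" (no result reported), so no number is available for it. Compound 3 `CC(=O)n1cc(/C=C(/C(=O)O)c2ccc(OCc3ccccc3)cc2)c2cc(OCc3ccccc3)ccc21` gives 44100 nM, a number that sits within the usual scatter of the value for compound 1, so the two cannot be told apart. Compound 4 `CC(=O)n1cc(/C=C(/C(=O)O)c2ccc(Cl)cc2)c2cc(OCc3ccccc3)ccc21` differs from compound 3 by chloro in place of benzyloxy on an aromatic carbon. Among the measured compounds shown here, no pair of measured compounds shows this kind of change, so there is no measured step to lean on. Compound 4 is expected to land close to compound 3, with a step from compound 3 to compound 4 of a 1.1-fold higher number from compound 3 to compound 4 (0.05 log units; within the scatter) that would not clearly exceed the scatter. The estimate for compound 4 is 50000 nM, within a range from 15000 nM to 160000 nM.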

Compound 4, half-maximal inhibitory concentration: 52300 nM
Compound 4: the middle estimate sits 1.0-fold (0.02 log units) below what was measured, and the stated range covers the measured number.
By their numbers in this assay, from the lowest: compounds 3, 1 and 4 (each within the scatter of the next).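

In this assay, replacing the large benzyloxy with a single chloro on this aromatic carbon gives a 1.2-fold higher number from compound 3 to compound 4 (0.07 log units; within the scatter), so this benzyloxy, with its whole aromatic ring, can go without a readable change in cytotoxicity. The other listed change, 4-chlorophenyl in place of 3-methoxyphenyl on the double-bonded chain carbon, gives a 1.2-fold higher number from compound 1 to compound 4 (0.06 log units; within the scatter), again without a readable change. No measurement here explains why these numbers stay together. As far as these compounds go, whether an amine or a hydroxyl on this aromatic carbon would move the number remains open, as does whether any compound with the shared core can reach a much lower number.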